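The compounds below may be only part of what the source reports. "The series", "measured", "known", "first", "only" and "open" are said of these compounds alone.

Compound 1 `O=C(NCCO)c1cccc(Nc2ncc(F)c(Nc3ccc(F)cc3)n2)c1`: in a functional assay on KBVIN cells (Homo sapiens) for antiproliferative activity, read by sulforhodamine B assay, with a stated time of 3 days (on this read-out lower numbers stand for stronger inhibition of growth and higher numbers for weaker inhibition of growth), compound 1 gives 21400 nM
Compound 2 `Cn1ccnc1NC(=O)c1cccc(Nc2ncc(F)c(Nc3ccc(F)cc3)n2)c1`: compound 2 gives 13100 nM
Compound 3 `CN(C)CC(=O)Nc1cccc(Nc2ncc(F)c(Nc3ccc(F)cc3)n2)c1`: compound 3 gives 1810 nM

Compound 3 has the lowest number of the three: the step from compound 1 is a 12-fold lower number from compound 1 to compound 3 (1.07 log units; beyond the scatter), and that from compound 2 is a 7.2-fold lower number from compound 2 to compound 3 (0.86 log units; beyond the scatter), while a 1.6-fold lower number from compound 1 to compound 2 (0.21 log units; within the scatter). Compound 4 `COc1ccc(NC(=O)c2cccc(Nc3ncc(F)c(Nc4ccc(F)cc4)n3)c2)cc1` carries (4-methoxyphenyl)carbamoyl in place of (((dimethylamino)methyl)carbonyl)amino on an aromatic carbon. For the measured compounds named here, the two steps ending at compound 3 both bear on this change, since in both a carbamoyl group gave the higher number; a (4-methoxyphenyl)carbamoyl group has no direct precedent here. Compound 4 is therefore expected to show a higher number, a 4.4-fold higher number from compound 3 to compound 4 (0.65 log units; beyond the scatter), with an estimate of 8000 nM and a range from 2500 nM to 25000 nM.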

Compound 4, concentration for 50% growth inhibition: 15700 nM
Beside the measured number, compound 4's estimate is 2.0-fold (0.29 log units) below it; the measured number falls inside the stated range.
By their numbers in this assay, from the lowest: compound 3; then compounds 2, 4 and 1 (each within the scatter of the next).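

In this assay, a (4-methoxyphenyl)carbamoyl group at this position does not match the (((dimethylamino)methyl)carbonyl)amino group, with an 8.7-fold higher number from compound 3 to compound 4 (0.94 log units; beyond the scatter). Placing this aromatic ring on the amide nitrogen leaves the number within the scatter of the other two carbamoyl compounds, with a 1.2-fold higher number from compound 2 to compound 4 (0.08 log units; within the scatter) and a 1.4-fold lower number from compound 1 to compound 4 (0.13 log units; within the scatter), so compound 3 alone stands apart among the four. No evidence available here accounts for this gap. Compound 3 differs from the carbamoyl compounds in both its reversed amide and its dimethylamino group, so the compounds shown leave open which matters; a plain acetylamino group, or a carbamoyl group carrying a 2-(dimethylamino)ethyl chain, would separate the two.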